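The compounds below may be only part of what the source reports. "The series", "measured", "known", "first", "only" and "open" are said of these compounds alone.

Compound 1 `CCCCCCOc1ccc(-n2cnnc2)cc1` was tested in a functional assay on the whole organism (strain C57B/6) with Mus musculus as the target, in the maximal electroshock model (on this read-out higher numbers stand for an effect only at larger amounts of compound and lower numbers for an effect already at smaller amounts), where compound 1 gives 9.8 mg/kg. Going by the values given here, this is the lowest of the three numbers so far: compound 2 `CCCCCCOc1ccc(-n2cnnc2CC)cc1` gives 13.2 mg/kg and compound 3 `CCCCCCOc1ccc(-n2cnnc2-c2ccc(F)cc2)cc1` gives 22 mg/kg, with a 1.3-fold higher number from compound 1 to compound 2 (0.13 log units; within the scatter) and a 2.2-fold higher number from compound 1 to compound 3 (0.35 log units; beyond the scatter). Compound 4 `CCCCCCOc1ccc(-n2cnnc2-c2ccc(C)cc2)cc1` has not yet been measured; it differs from compound 1 in one place: 4-methylphenyl in place of hydrogen on an aromatic carbon. Among the compounds with values here, the closest precedent is a 2.2-fold higher number from compound 1 to compound 3 (0.35 log units; beyond the scatter), where a six-membered aromatic ring also entered on an aromatic carbon and brought a modest rise, while the smaller ethyl group in a 1.3-fold higher number from compound 1 to compound 2 (0.13 log units; within the scatter) stayed within the scatter. A similar modest rise is therefore expected for compound 4, a 2.0-fold higher number from compound 1 to compound 4 (0.31 log units; beyond the scatter). Compound 4 is estimated at 20 mg/kg, with a range from 11 mg/kg to 38 mg/kg.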

Compound 4, dose for half-maximal effect: 11.4 mg/kg
Estimate against measurement, compound 4: 1.8-fold (0.24 log units) above; measured number inside the range.
By their numbers in this assay, from the lowest: compounds 1, 4, 2 and 3 (each within the scatter of the next, the first and the last beyond it).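

With 4-methylphenyl on the aromatic carbon between two ring nitrogen atoms, the step from hydrogen is a 1.2-fold higher number from compound 1 to compound 4 (0.07 log units; within the scatter), and the step from ethyl is a 1.2-fold lower number from compound 2 to compound 4 (0.06 log units; within the scatter), so this large group shows no measurable cost here. Swapping the fluoro for methyl on the added ring gives a 1.9-fold lower number from compound 3 to compound 4 (0.29 log units; within the scatter), which means these two aryl groups cannot be told apart. No data here explain these numbers. From the compounds shown here alone, whether an amine or a carboxylic acid on the added ring would keep this level remains open.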